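The source may hold more compounds than are shown below. What is called first, only, known or untested is meant among the compounds shown, and "the series" means these compounds.

Three compounds share one core and were tested in a functional assay on the whole organism (stomach) with Rattus norvegicus as the target; on this read-out higher numbers stand for an effect only at larger amounts of compound and lower numbers for an effect already at smaller amounts. Compound 1 `N#CNC(=N)NCCCCn1nc(-c2ccccc2)ccc1=O` gives 77.2 mg/kg in this assay. Compound 2 `C/N=C(\S)NCCCCn1nc(-c2ccccc2)ccc1=O` gives 28.9 mg/kg, a step of a 2.7-fold lower number from compound 1 to compound 2 (0.43 log units; beyond the scatter). Compound 3 `C/N=C(/NC#N)N(C)CCCCn1nc(-c2ccccc2)ccc1=O` reaches only a limit in this assay, > 100 mg/kg, so its standing is known only as a floor (the limit of > 100 mg/kg in this assay, at which 1 of the 3 values shown sits). The step to it from compound 1 was an at least 1.2-fold higher number from compound 1 to compound 3 (0.11 log units; that floor lies within the scatter), and from compound 2 it was an at least 3.4-fold higher number from compound 2 to compound 3 (0.53 log units; beyond the scatter). Compound 4 `CC(C)(C)/N=C(\S)NCCCCn1nc(-c2ccccc2)ccc1=O` carries a group of 8 heavy atoms (5 carbon, 2 nitrogen, 1 sulfur; no ring) in place of a group of 8 heavy atoms (4 carbon, 4 nitrogen; no ring), on a saturated chain carbon, four bonds along the chain from an aromatic nitrogen, which largely undoes the change behind an at least 3.4-fold higher number from compound 2 to compound 3 (0.53 log units; beyond the scatter). The number for compound 4 is therefore expected to drop, with a step of an at least 2.8-fold lower number from compound 3 to compound 4 (0.45 log units; beyond the scatter). Compound 4 is estimated at 35 mg/kg, with a range from 12 mg/kg to 100 mg/kg.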

Compound 4, dose for half-maximal effect: > 100 mg/kg
Compound 4: a limit, no number; the forecaster's own chance of this, stated with the estimate: 20%; middle value at least 2.8-fold (0.45 log units) away from the limit.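

In this assay compound 4 reaches only a limit, > 100 mg/kg. Tert-butyl in place of methyl on a double-bonded nitrogen gives an at least 3.4-fold higher number from compound 2 to compound 4 (0.53 log units; beyond the scatter), so the sulfur-bearing group alone does not secure the lower number of compound 2. The comparison with the cyano-bearing compound gives an at least 1.2-fold higher number from compound 1 to compound 4 (0.11 log units; that floor lies within the scatter), while the step from compound 3 cannot be read, since both values are limits: the limit of > 100 mg/kg in this assay, at which 2 of the 4 values shown sit.

On these data alone, how far compound 3 and compound 4 lie past the limit stays open. Also open, as far as these compounds go, is whether ethyl or isopropyl on that nitrogen would keep the value of compound 2.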